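This account rests on a few compounds, and the source may have more. Where it says the series, first, only, none or still open, it means among the compounds named here.

Compound 1 `COc1ccc(N2CCN(Cc3csc(N)c3C(=O)c3ccc(Cl)cc3)CC2)cc1` gives -52% in a functional assay on CHO cells with adenosine receptor A1 (Homo sapiens) as the target, read by cAMP accumulation and immunoassay, with a stated time of 6 min, tested at 10 uM; a higher number here means a weaker effect of the compound at the concentration tested, a lower number a stronger effect.
Compound 2 `Nc1scc(CN2CCN(c3ccc(C(F)(F)F)cc3)CC2)c1C(=O)c1cccc(C(F)(F)F)c1` gives -47% in this assay.
Compound 3 `Nc1scc(CN2CCN(c3c(F)cccc3F)CC2)c1C(=O)c1cccc(C(F)(F)F)c1` gives 4% in this assay.

Compound 1 has the lowest number of the three in this assay. Compound 2 lies within the usual scatter of it, so the two cannot be told apart, while compound 3 lies far higher. For the measured compounds named here, the one measured step between neighbours, a number 51 percentage points higher from compound 2 to compound 3 (beyond the scatter), shows how much a change of the group on the ring nitrogen can move the number.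

Compound 4 `Nc1scc(CN2CCN(C3CCCCCC3)CC2)c1C(=O)c1ccc(Cl)cc1` has not yet been measured in this assay. It differs from compound 1 in one place: cycloheptyl in place of 4-methoxyphenyl on an amine nitrogen in a ring. Going by the values given here, no measured step exchanges an aromatic ring for a non-aromatic one at that nitrogen, so there is no direct guide. Among the compounds with values here, the number for compound 4 is nevertheless expected to move upward, by a number 32 percentage points higher from compound 1 to compound 4 (beyond the scatter), because the only change made at that nitrogen so far, a number 51 percentage points higher from compound 2 to compound 3 (beyond the scatter), was large. Compound 4 is therefore estimated at -20%, within a range from -60% to 20%.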

Compound 4, a percentage reported as activity, at one concentration (the size of the read-out at that concentration, not a potency): -25%
The estimate for compound 4 lay 5 percentage points above the measured number, and the stated range covers the measured number.
By their numbers in this assay, from the lowest: compounds 1 and 2 (each within the scatter of the next); then compound 4; then compound 3.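

For the compounds shown here, the step of a number 27 percentage points higher from compound 1 to compound 4 (beyond the scatter) is the first measured exchange of an aromatic ring for a non-aromatic one on this amine nitrogen, and in this assay the number stays below zero, so an aromatic ring is not required there for a negative read-out. The change also removes the oxygen of 4-methoxyphenyl and alters the ring size, so this single step cannot separate the effects of those differences from that of losing aromaticity. Nothing available explains the size of this step.

As far as these compounds go, whether a cyclopentyl ring, an open butyl chain or a benzyl group at this nitrogen would give a number nearer compound 1 or compound 3 remains open. From the compounds shown here alone, it is also open whether cycloheptyl would give a similar step on the core of compound 2, which carries trifluoromethyl rather than chlorine on its other ring.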